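Urea anilide swap: from iodophenyl to methylphenyl

The compounds below may be only part of what the source reports. "The series", "measured", "known", "first", "only" and "open" are said of these compounds alone.

Compound 2 `CCc1nc2ccccc2c(=O)n1NC(=O)Nc1ccc(I)cc1` gives 55% in a functional assay on the whole organism (strain albino) with Mus musculus as the target, at a dose of 100 mg/kg by the intraperitoneal route (on this read-out higher numbers stand for more inhibition at the one dose given (going by the name of the read-out) and lower numbers for less inhibition), close to compound 1 `CCc1ccc(NC(=O)Nn2c(CC)nc3ccccc3c2=O)cc1`, which gives 58%; the step of a number 3 percentage points lower from compound 1 to compound 2 (within the scatter) shows that the change on that aromatic ring changed little. Compound 3 `CCc1nc2ccccc2c(=O)n1NC(=O)Nc1ccccc1C` differs from compound 2 by 2-methylphenyl in place of 4-iodophenyl on an amide-type nitrogen. Going by the values given here, the only step that bears on this is the one from compound 1 to compound 2, which lay within the scatter, so a step of about a number 1 percentage points lower from compound 2 to compound 3 (within the scatter) is expected, with no clear direction. Compound 3 is therefore estimated at 54%, with a range from 35% to 72%.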

Compound 3, a percentage reported as inhibition, in the whole organism at one dose (the size of the read-out at that dose, not a potency): 54%
Beside the measured number, compound 3's estimate shows no gap at the digits printed, within the range that was stated.
By their numbers in this assay, from the lowest: compounds 3, 2 and 1 (each within the scatter of the next).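

In this assay, 2-methylphenyl in place of 4-iodophenyl gives a number 1 percentage points lower from compound 2 to compound 3 (within the scatter) and in place of 4-ethylphenyl gives a number 4 percentage points lower from compound 1 to compound 3 (within the scatter). Among these three compounds, the group on this ring can therefore differ in its place as well as its kind with the read-out staying within the scatter, which the 4-ethylphenyl and 4-iodophenyl pair alone could not show. Nothing available explains why the three compounds read alike. As far as these compounds go, it remains open whether a carboxylic acid or an amine on this ring would stay within that range.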